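A methyl added para to the sulfonyl: expected effect

A few compounds are considered here, and "the series" means these few. Any claim that something is new, unique, unknown or untested is made for them only; others in the source may bear on it.

Compound 1, `COc1ccc(/C=C2\CCC=CC2=O)cc1`, and compound 2, `COc1ccc(/C=C2\CCC=CC2=O)c(C)c1`, share a core and differ by one change: methyl in place of hydrogen on an aromatic carbon. In a functional assay on MDA-MB-231 cells (Homo sapiens) for antiproliferative activity, read by sulforhodamine B assay, with a stated time of 72 h (on this read-out lower numbers stand for stronger inhibition and higher numbers for weaker inhibition), compound 1 gives 1620 nM, and compound 2 gives 1070 nM. The measured step is a 1.5-fold lower number from compound 1 to compound 2 (0.18 log units; within the scatter), so the two values lie within the scatter of each other and tell nothing about a change in either direction.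

Compound 3, `COc1cc(/C=C2\CN(S(=O)(=O)c3ccccc3)C=CC2=O)cc(OC)c1OC`, is built on a different core; the difference between the two cores is not broken down here. In this assay compound 3 gives 23300 nM, the highest number among the three measured compounds and well beyond the scatter from both compound 1 and compound 2. Compound 4, `COc1cc(/C=C2\CN(S(=O)(=O)c3ccc(C)cc3)C=CC2=O)cc(OC)c1OC`, has not yet been measured. It differs from compound 3 by methyl in place of hydrogen on an aromatic carbon. Within the data shown here, this is the same kind of change as the one from compound 1 to compound 2, but not the same: there the methyl enters ortho to a group of 8 heavy atoms and meta to a methoxy group, whereas here it enters para to a large group on the phenylsulfonyl, giving (4-methylphenyl)sulfonyl.

The step expected here is a 1.3-fold lower number from compound 3 to compound 4 (0.11 log units; within the scatter), because the matching change in the measured pair gave a 1.5-fold lower number from compound 1 to compound 2 (0.18 log units; within the scatter). On that basis, compound 4 is expected to give about 18000 nM in this assay, most likely between 8000 nM and 40000 nM.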

Compound 4, half-maximal inhibitory concentration: 22200 nM
Compound 4: middle estimate off by 1.2-fold (0.09 log units), on the low side; the measured number falls inside the stated range.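

The new step is a 1.0-fold lower number from compound 3 to compound 4 (0.02 log units; within the scatter), so compound 3 and compound 4 cannot be told apart in this assay, and turning phenylsulfonyl into (4-methylphenyl)sulfonyl leaves no readable mark on this measurement. Set beside the earlier pair, the same swap of hydrogen for methyl gives steps that agree on the two cores as far as this measurement can tell: the same change on two cores in this assay, a 1.5-fold lower number (0.18 log units; within the scatter) from compound 1 to compound 2 and a 1.0-fold lower number (0.02 log units; within the scatter) from compound 3 to compound 4, 1.4-fold (0.16 log units) apart, within the scatter of two such steps. Among these compounds, this shows that, in these two pairs, the change carries across cores in the limited sense that neither step rises above the noise, but it does not show that a methyl never matters, since there are only two pairs, the methyl sits in a different place in each, and two steps that are both too small to read say little about whether a real effect would transfer.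

The compounds shown leave open whether something other than methyl at this place on the ring, such as an amine or a carboxylic acid, would give a step beyond the scatter. They also leave open whether a longer chain, such as ethyl or propyl, would do so in place of the methyl.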